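The source may report more compounds than this note shows. Statements on the series, on what has been measured and on what is new or still open speak of the compounds shown alone.

Measured so far:
- compound 1 `Cc1c(CO)cc2n1[C@@H](c1ccccc1)SC2`: 26400 nM
- compound 2 `Cc1cc(CO)c2n1[C@@H](c1ccccc1)SC2`: 110000 nM
- compound 3 `Cc1c(COC(=O)NCc2ccccc2)cc2n1[C@@H](c1ccccc1)SC2`: 8800 nM

In a functional assay on MCF7 cells (Homo sapiens) for cytotoxicity, read by MTT assay, with a stated time of 24 h (on this read-out higher numbers stand for weaker inhibition and lower numbers for stronger inhibition), compound 2 gives the highest number of the three, beyond the scatter from compound 1 and from compound 3. Compound 4 `Cc1c(CO)c(CO)c2n1[C@@H](c1ccccc1)SC2` is not yet measured. It differs from compound 2 by hydroxymethyl in place of hydrogen on an aromatic carbon. Among the compounds with values here, no step between two measured compounds of this kind is available, so the size of the expected step rests only on the values shown. Compound 1, which carries a hydroxymethyl group on the other ring carbon, gives 26400 nM in this assay, a lower number than compound 2. The second hydroxymethyl group is therefore expected to move the number down rather than up, by a moderate step of a 2.2-fold lower number from compound 2 to compound 4 (0.34 log units; beyond the scatter). For compound 4 the estimate in this assay is 50000 nM, with a range from 15000 nM to 200000 nM.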

Compound 4, half-maximal inhibitory concentration: 12200 nM
The estimate for compound 4 lay 4.1-fold (0.61 log units) above the measured number; the measured number lies below the stated range.
By their numbers in this assay, from the lowest: compounds 3 and 4 (each within the scatter of the next); then compound 1; then compound 2.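

In this assay, within the data shown here, hydroxymethyl in place of hydrogen on this aromatic carbon, the ring atom next to the one bearing a methyl group, gives a 9.0-fold lower number from compound 2 to compound 4 (0.96 log units; beyond the scatter) and so lowers the number when a second hydroxymethyl group is already present. Read the other way, the change at the ring carbon carrying the hydroxymethyl group of compound 2 gives a 2.2-fold lower number from compound 1 to compound 4 (0.34 log units; beyond the scatter) and so also lowers the number. The two hydroxymethyl groups are therefore compatible on the shared core, with both steps beyond the scatter.

Nothing available explains either step. From the compounds shown here alone, whether an amine, a carboxylic acid or a longer chain on this aromatic carbon would lower the number as well remains open.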